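Compound 3 to compound 4: isopropyl gives way to propyl

The source may report more compounds than this note shows. Statements on the series, on what has been measured and on what is new or still open speak of the compounds shown alone.

Values in an ADME assay on CCRF-HSB-2 cells (Homo sapiens) for cytotoxicity, with a stated time of 7 days (on this read-out lower numbers stand for higher toxicity in this test and higher numbers for lower toxicity in this test), are as follows:
- Compound 1 `CNc1nc(N)nc2c1ncn2/C=C1/CC1(CO)CO` gives > 20000 nM as a limit
- Compound 2 `Nc1nc(OCC(F)(F)F)c2ncn(/C=C3/CC3(CO)CO)c2n1` gives > 20000 nM as a limit
- Compound 3 `CC(C)Nc1nc(N)nc2c1ncn2/C=C1/CC1(CO)CO` gives > 20000 nM as a limit
- Compound 4 `CCCNc1nc(N)nc2c1ncn2/C=C1/CC1(CO)CO` is not yet measured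

Compound 3 reaches only a limit (> 20000 nM) and no number. The whole series ends there (the limit of > 20000 nM in this assay, at which 3 of the 3 values shown sit). The change to compound 4 is propyl in place of isopropyl on a nitrogen on an aromatic ring. The nearest measured change is (a step that the two limits leave unreadable from compound 1 to compound 3), with isopropyl in place of methyl on a nitrogen on an aromatic ring. The other two, (a step that the two limits leave unreadable from compound 1 to compound 2) and (a step that the two limits leave unreadable from compound 2 to compound 3), are no more readable. With compound 3 reached only through such a step (a step that the two limits leave unreadable from compound 1 to compound 3), no step beyond the usual scatter is expected in this assay and no direction can be given. The expected step is (a number no higher from compound 3 to compound 4 (the limit leaves the size open)). Compound 4 is estimated at 20000 nM with an expected range from 9000 nM to 40000 nM and will probably again be reported only as a limit.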

Compound 4, half-maximal cytotoxic concentration: > 20000 nM
Compound 4 was reported as a limit (the forecaster's own chance of this, stated with the estimate: 85%); the middle value sits exactly at the limit.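

No new step can be read between compound 4 and compound 1, compound 2 or compound 3, since each value is only a limit: the limit of > 20000 nM in this assay, at which 4 of the 4 values shown sit.

The compounds shown leave open whether any of these groups differ in this assay.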